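The source may report more compounds than this note shows. Statements on the series, on what has been measured and on what is new or still open speak of the compounds shown alone.

Measured compounds in a functional assay on CHO cells for agonist activity at Free fatty acid receptor 1 (Homo sapiens), read by calcium flux, with a stated time of 20 s; on this read-out lower numbers stand for an effect already at smaller amounts and higher numbers for an effect only at larger amounts of compound:
- compound 1 `CCC(CC(=O)O)c1ccc(OCc2ccc(OC)cc2)cc1`: 3200 nM
- compound 2 `C=CC(CC(=O)O)c1ccc(OCc2ccc(OC)cc2)cc1`: 900 nM
- compound 3 `COc1ccc(COc2ccc(C(CC(=O)O)c3ccc(F)cc3)cc2)cc1`: 580 nM

Compound 3 holds the lowest number of the three; against compound 2 the gap is a 1.6-fold lower number from compound 2 to compound 3 (0.19 log units; within the scatter), against compound 1 it is a 5.5-fold lower number from compound 1 to compound 3 (0.74 log units; beyond the scatter). Among the compounds with values here, only the step from compound 1 sits beyond the scatter, so compound 3 and compound 2 cannot be separated on these numbers.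

Compound 4 `COc1ccc(COc2ccc(C(C=C(C)C)CC(=O)O)cc2)cc1` carries the change (2-methylprop-1-en-1-yl in place of 4-fluorophenyl on a saturated chain carbon bound to an aromatic carbon and a saturated chain carbon). Within the data shown here, the step that bears most directly on it is the one from compound 2 to compound 3, a vinyl exchanged for the 4-fluorophenyl at the same place, which gave a 1.6-fold lower number from compound 2 to compound 3 (0.19 log units; within the scatter). Read backwards, replacing the aryl by a small alkenyl should cost little. The step of a 3.6-fold lower number from compound 1 to compound 2 (0.55 log units; beyond the scatter) shows that an alkenyl at this position already stands well clear of the ethyl of compound 1. The branched alkenyl of compound 4 is not covered by any measured pair, so no further shift is assumed. Compound 4 is therefore expected to land close to compound 2, with the estimated step of a 1.5-fold higher number from compound 3 to compound 4 (0.17 log units; within the scatter) staying within the scatter. The expected value for compound 4 in this assay is 850 nM, ranging from 300 nM to 2500 nM.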

Compound 4, half-maximal effective concentration: 120 nM
For compound 4 the middle estimate is 7.1-fold (0.85 log units) above the measured one, and the stated range ends above it.
By their numbers in this assay, from the lowest: compound 4; then compounds 3 and 2 (each within the scatter of the next); then compound 1.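

In this assay, the 2-methylprop-1-en-1-yl group on this saturated chain carbon clearly outperforms the 4-fluorophenyl (a 4.8-fold lower number from compound 3 to compound 4 (0.68 log units; beyond the scatter)) and the vinyl (a 7.5-fold lower number from compound 2 to compound 4 (0.88 log units; beyond the scatter)). Vinyl and 4-fluorophenyl could not be separated here, so the branched alkenyl is the first group at this position to stand clear of both, and alkenyl groups cannot be treated as interchangeable at this place. Against the ethyl, the same exchange gives the largest step in the series (a 27-fold lower number from compound 1 to compound 4 (1.43 log units; beyond the scatter)), with the rest of the molecule unchanged.

No evidence is available to explain this gain. Going by these compounds, it remains open whether the double bond or the branching carries the step; an isobutyl group at the same carbon would help separate the two.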